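Swapping the Ring on the Sulfonamide Nitrogen

The compounds below may be only part of what the source reports. "The series", "measured", "known", "first", "only" and "open" are said of these compounds alone.

Measured compounds:
compound 1 `C=C1CC[C@@H]2[C@](C)(COC(C)=O)[C@H](OC(C)=O)CC[C@@]2(C)[C@H]1CC(Nc1ccc(S(=O)(=O)Nc2ccc(Cl)nn2)cc1)C1=CCOC1=O`: > 100000 nM
compound 2 `C=C1CC[C@@H]2[C@](C)(COC(C)=O)[C@H](OC(C)=O)CC[C@@]2(C)[C@H]1CC(Nc1ccc(S(=O)(=O)Nc2cc(C)on2)cc1)C1=CCOC1=O`: > 100000 nM

In a functional assay on MOLT-4 cells (Homo sapiens) for inhibition, read by sulforhodamine B assay, with a stated time of 48 h (on this read-out lower numbers stand for higher toxicity in this test and higher numbers for lower toxicity in this test), compound 1 gives > 100000 nM, which is a limit of the assay rather than a number. Compound 2 gives > 100000 nM in this assay, again only a limit. The step between them, a step that the two limits leave unreadable from compound 1 to compound 2, cannot be sized, because the limit of > 100000 nM in this assay, at which 2 of the 2 values shown sit, is where both values sit.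

Compound 3 `C=C1CC[C@@H]2[C@](C)(COC(C)=O)[C@H](OC(C)=O)CC[C@@]2(C)[C@H]1CC(Nc1ccc(S(=O)(=O)Nc2nccc(C)n2)cc1)C1=CCOC1=O` differs from compound 2 by 4-methylpyrimidin-2-yl in place of 5-methyl-1,2-oxazol-3-yl on a sulfonamide nitrogen. Within the data shown here, the single measured step concerns a different exchange on the same sulfonamide nitrogen and its size is unreadable, so it gives no ground to expect any shift beyond the scatter in this assay for this new exchange. Compound 3 is therefore expected to give 150000 nM, with a range from 60000 nM to 400000 nM, most likely again returned as a limit. The step from compound 2 to compound 3 that this estimate means is a step that the limit leaves unreadable from compound 2 to compound 3, expected to stay within the scatter.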

Compound 3, concentration lethal to 50% of the cells: > 100000 nM
Compound 3: only a limit was reported (the forecaster's own chance of this, stated with the estimate: 85%); the middle value lies beyond the limit too.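

No step among compound 1, compound 2 and compound 3 can be read, because all three values are limits rather than numbers: the limit of > 100000 nM in this assay, at which 3 of the 3 values shown sit.

The compounds shown leave open whether the three rings on the sulfonamide nitrogen differ at all in this assay.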